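A few compounds are considered here, and "the series" means these few. Any claim that something is new, unique, unknown or untested is made for them only; others in the source may bear on it.

Compound 2 `FCCOc1cccc(-c2cn(C3CN4CCC3CC4)nn2)c1` holds the lowest of the two numbers seen so far: in an assay on HEK293 cells for displacement of a labelled ligand from Neuronal acetylcholine receptor; alpha3/beta4 (Homo sapiens), read by scintillation counting, with a stated time of 120 min (on this read-out higher numbers stand for weaker inhibition and lower numbers for stronger inhibition), compound 2 gives 20.9 nM, while compound 1 `FCCOc1cccc(-c2cn([C@H]3CN4CCC3CC4)nn2)c1` gives 558 nM. The step of a 27-fold lower number from compound 1 to compound 2 (1.43 log units; beyond the scatter) is large, and the pair differs only in that (the fact that one of compounds 1 and 2 is drawn with a defined configuration and the other without, at the place where they differ). Compound 3 `FCCOc1cccc(-c2cn([C@@H]3CN4CCC3CC4)nn2)c1` differs from compound 2 in this way: the two compounds have the same atoms and bonds; at least one stereo element is drawn with a configuration in one of them and without one in the other: 1 of 3 stereo elements differ; a stereocentre at a saturated ring carbon is drawn without a configuration in compound 2 and S in compound 3. The configuration drawn in compound 1 carries the weaker number, 558 nM, so the other drawn configuration is the one expected to carry the stronger number. The step of a 1.9-fold lower number from compound 2 to compound 3 (0.28 log units; within the scatter) is therefore expected to be moderate, toward stronger inhibition. Compound 3 is estimated at 11 nM, within 4 nM to 30 nM.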

Compound 3, inhibition constant: 11.8 nM
Compound 3: middle estimate off by 1.1-fold (0.03 log units), on the low side, within the range that was stated.
By their numbers in this assay, from the lowest: compounds 3 and 2 (each within the scatter of the next); then compound 1.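

The full reach of this stereocentre at the saturated ring carbon shows in this assay as a 47-fold lower number from compound 1 to compound 3 (1.67 log units; beyond the scatter) with nothing else in the structure changed. Against that, a 1.8-fold lower number from compound 2 to compound 3 (0.25 log units; within the scatter) leaves the S form and the form drawn without a configuration indistinguishable on this read-out. Among these three compounds, only the R drawing stands apart.

On these data alone, whether the S centre keeps its advantage over the R centre when a longer chain or a nitrile replaces the fluorinated ether chain on the shared core remains open.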